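A Fluoro Removed From the Shared Core

A few compounds are considered here, and "the series" means these few. Any claim that something is new, unique, unknown or untested is made for them only; others in the source may bear on it.

Of the compounds shown here, three share a hydrazone-linked thiazole core and have been measured in a functional assay, read by spectrophotometry, with a stated time of 15 min, tested at 100 ug/mL; on this read-out lower numbers stand for a weaker effect and higher numbers for a stronger effect at the one concentration tested. Compound 1, `COC(=O)c1cc(-c2csc(N/N=C/c3cccs3)n2)ccc1OCc1ccccc1`, gives 92.4% in this assay. Compound 2, `Clc1ccc(-c2csc(N/N=C/c3cccs3)n2)cc1`, gives 87.1%. Compound 3, `Fc1ccc(-c2csc(N/N=C/c3ccc(Cl)cc3Cl)n2)cc1`, gives 95.6%. Compound 3 stands alongside the other two rather than apart from them: its gap to compound 1 and its gap to compound 2 both fall within the usual scatter of repeated measurements, so the three numbers cannot be set in any order against one another.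

The unmeasured compound 4, `Clc1ccc(/C=N/Nc2nc(-c3ccccc3)cs2)c(Cl)c1`, differs from compound 3 in a single place.

hydrogen in place of fluoro on an aromatic carbon

The fluoro leaves an aromatic carbon of a six-membered aromatic ring of carbon only, and a hydrogen takes its place; no ring, donor or acceptor is lost. Among the measured compounds shown here, no pair of measured compounds differs in exactly this way, so no measured step guides the expectation, and the compounds at hand all sit close together. The step is therefore expected to be small, a number 5.6 percentage points lower from compound 3 to compound 4 (within the scatter), not beyond the scatter. Compound 4 is expected to give 90%, with a range from 78% to 97%.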

Compound 4, a percentage reported as inhibition, at one concentration (the size of the read-out at that concentration, not a potency): 87.4%
For compound 4 the middle estimate is 2.6 percentage points above the measured one; low and high end bracket the measured number.
By their numbers in this assay, from the lowest: compounds 2, 4, 1 and 3 (each within the scatter of the next).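

In this assay, among the compounds shown here, the change from 4-fluorophenyl to phenyl gives a number 8.2 percentage points lower from compound 3 to compound 4 (within the scatter), and this is the first step between two compounds that differ in one place. The earlier compounds shown here differed in several places at once and could say nothing about any single group; this pair shows that, at the one concentration tested, the read-out does not separate fluoro from hydrogen on this aromatic carbon, para to a large group, and that compound 4 keeps a number of 87.4% without the fluoro. No measurement at hand offers an explanation for how these two compounds read against each other, and a single step cannot show whether the fluoro has any part in the effect.

Still open, going by these compounds, is whether a larger or quite different group at this place, such as an amine, a carboxylic acid or a methoxy group, would give a number beyond the scatter from those of compound 3 and compound 4. Also open, on these data alone, is whether fluoro and hydrogen would still read alike at lower concentrations, or on compounds with other groups elsewhere on the shared core.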